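The source may hold more compounds than are shown below. What is called first, only, known or untested is meant among the compounds shown, and "the series" means these compounds.

Compound 3 `COC(=O)c1sc2cc(C#Cc3cccc(OC)c3)cnc2c1N` stands at the weak end of the three measured analogues. In a functional assay on A375-C5 cells (Homo sapiens) for inhibition, read by sulforhodamine B assay, with a stated time of 48 h (a lower number here means a stronger inhibitor of growth, a higher number a weaker inhibitor of growth), compound 3 gives only a limit of the assay, > 75000 nM. Compound 1 `COC(=O)c1sc2cc(C#Cc3ccccn3)cnc2c1N` gives 13900 nM in this assay, and compound 2 `COC(=O)c1sc2cc(C#Cc3ccsc3)cnc2c1N` gives 29600 nM. The steps of an at least 5.3-fold higher number from compound 1 to compound 3 (0.73 log units; beyond the scatter) and an at least 2.5-fold higher number from compound 2 to compound 3 (0.40 log units; beyond the scatter) both run into (the limit of > 75000 nM in this assay, at which 1 of the 3 values shown sits). Compound 4 `COC(=O)c1sc2cc(C#Cc3ccccc3)cnc2c1N` differs from compound 3 by hydrogen in place of methoxy on an aromatic carbon. Among the measured compounds shown here, no measured step removes a methoxy; the measured steps only exchange the whole ring on the triple-bonded carbon, and they were modest. The expected step of an at least 1.2-fold lower number from compound 3 to compound 4 (0.09 log units; that floor lies within the scatter) is therefore small. Compound 4 is estimated at 60000 nM in this assay, between 20000 nM and 150000 nM.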

Compound 4, concentration for 50% growth inhibition: > 150000 nM
Compound 4: only a limit was reported; the forecaster's own chance of this, stated with the estimate: 50%; at least 2.5-fold (0.39 log units) between middle value and limit.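

Compound 3 and compound 4 both carry only limits in this assay, so the step between them cannot be read. The new information lies in the other two steps, an at least 5.0-fold higher number from compound 2 to compound 4 (0.70 log units; beyond the scatter) and an at least 10-fold higher number from compound 1 to compound 4 (1.03 log units; beyond the scatter): the plain phenyl, without the methoxy, also falls short of the pyridin-2-yl and thiophen-3-yl rings. On the triple-bonded carbon, the phenyl ring with or without the methoxy therefore reads weaker than the rings of compound 1 and compound 2. As far as these compounds go, whether a phenyl carrying an amine or a carboxylic acid would reach the level of compound 1 stays open.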